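Amine substituents on the shared core: sizing compound 3

The source may report more compounds than this note shows. Statements on the series, on what has been measured and on what is new or still open speak of the compounds shown alone.

Measured so far:
compound 1 `COc1ccc(NC2=CC(=O)c3c(nc4n3[C@H]3OC[C@@H](O)[C@H]3OC4)C2=O)cc1` — > 8000 nM
compound 2 `O=C1C(N2CCC2)=CC(=O)c2c1nc1n2[C@H]2OC[C@@H](O)[C@H]2OC1` — > 16000 nM

For the measured compounds named here, both values measured so far are limits, not numbers. In a functional assay on HeLa cells (Homo sapiens) for inhibition, read by sulforhodamine B assay (on this read-out lower numbers stand for stronger inhibition and higher numbers for weaker inhibition), compound 1 reaches only a limit, > 8000 nM. Compound 2 likewise reaches only a limit in this assay, > 16000 nM. Compound 2 thus stands at the edge of what this assay reports; with both values limits, no order between compound 2 and compound 1 can be read. Going by the values given here, the one measured step, a step that the two limits leave unreadable from compound 1 to compound 2, remains unsized for that reason.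

Compound 3 `O=C1C(NC2CC2)=CC(=O)c2c1nc1n2[C@H]2OC[C@@H](O)[C@H]2OC1` differs from compound 2 by cyclopropylamino in place of azetidin-1-yl on a double-bonded ring carbon. Among the compounds with values here, no measured step bears on this change: the single step in the set cannot be sized, because the limit of > 16000 nM in this assay, at which 1 of the 2 values shown sits, and the limit of > 8000 nM in this assay, at which 1 of the 2 values shown sits, are where its two ends sit. The data therefore give no direction beyond the scatter, and the expectation is that compound 3 stays at or near the limit. Compound 3 is estimated in this assay at 20000 nM, with a range from 6000 nM to 60000 nM. The step that the limit leaves unreadable from compound 2 to compound 3 is accordingly expected to be none beyond the scatter.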

Compound 3, half-maximal inhibitory concentration: > 16000 nM
Compound 3: no number, only a limit; the forecaster's own chance of this, stated with the estimate: 75%; the middle value does not contradict the limit.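

In this assay compound 3 gives > 16000 nM, a limit and not a number. For the compounds shown here, all three values are limits, and no step among compound 1, compound 2 and compound 3 can be read. The compounds shown leave open whether any amine substituent on the shared core reaches a measurable value in this assay, and how these three compounds rank.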